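A few compounds are considered here, and "the series" means these few. Any claim that something is new, unique, unknown or untested is made for them only; others in the source may bear on it.

Measured so far:
- Compound 1, `CCc1cc(C(C)=O)c(O)cc1OCCCCC#N`: 57%
- Compound 2, `CCc1cc(C(C)=O)c(O)cc1OCCCCCC(C)(C)c1nnnn1C`: 59%
- Compound 3, `CCc1cc(C(C)=O)c(O)cc1OCCCCCC(C)(C)c1nnn(C)n1`: 66%

In an assay on isolated protein for binding affinity to leukotriene B4 receptor 1 (Homo sapiens), tested at 1 uM (on this read-out higher numbers stand for more inhibition at the one concentration tested (going by the name of the read-out) and lower numbers for less inhibition), compound 3 gives 66%, the highest of the three numbers, but its gaps to compound 2 and to compound 1 are both within the scatter, so the three numbers can only be called level. Going by the values given here, the only step that can be followed between two compounds differing in one place is a number 7 percentage points higher from compound 2 to compound 3 (within the scatter), a change of the tetrazole substitution that left the read-out essentially unchanged. Compound 4, `CCc1cc(C(C)=O)c(O)cc1OCCCCCCC(=O)Nc1nn[nH]n1`, differs from compound 3 by ((2H-tetrazol-5-yl)carbamoyl)methyl in place of 1-methyl-1-(2-methyl-2H-tetrazol-5-yl)ethyl on a saturated chain carbon, five bonds along the chain from an oxygen on an aromatic ring. Among the compounds with values here, no measured step covers this kind of change, since the chain end here gains an amide link and loses the two methyl groups along with the methyl on the ring. The three numbers in hand all lie close together despite different chain ends, so the step of a number 6 percentage points lower from compound 3 to compound 4 (within the scatter) is expected to stay within the scatter. On that basis compound 4 is estimated at 60%, within a range from 35% to 85%.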

Compound 4, a percentage reported as inhibition, at one concentration (the size of the read-out at that concentration, not a potency): 83%
Beside the measured number, compound 4's estimate is 23 percentage points below it, within the range that was stated.
By their numbers in this assay, from the lowest: compounds 1, 2 and 3 (each within the scatter of the next); then compound 4.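

In this assay, going by these compounds alone, the chain end had so far given no step beyond the scatter, but a number 17 percentage points higher from compound 3 to compound 4 (beyond the scatter) and a number 24 percentage points higher from compound 2 to compound 4 (beyond the scatter) both lie beyond it, so the number does respond to the group at this position. The entering ((2H-tetrazol-5-yl)carbamoyl)methyl keeps the heavy-atom count and a tetrazole ring of the group leaving compound 3, so neither of these alone accounts for the difference. It does bring an amide link with a carbonyl and hydrogen-bond donors, which that leaving group lacks, but no measurement at hand explains the rise.

The amide link, the free tetrazole hydrogen and the loss of the methyl groups all change together here, so the compounds shown cannot separate their contributions. As far as these compounds go, how a carboxylic acid at the chain end, or a longer chain carrying the same amide, would read remains open.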